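The source may report more compounds than this note shows. Statements on the series, on what has been measured and on what is new or still open speak of the compounds shown alone.

Compound 1 `CC1CC(=O)N(CC(=O)N2CCN(c3ccc(Cl)cc3)CC2)C1=O` gives 100 mg/kg in a functional assay on the whole organism (strain CD1) with Mus musculus as the target, in the maximal electroshock model, with a stated time of 0.5 h; a lower number here means that less compound is needed, a higher number that more compound is needed for the effect.
Compound 2 `CC1CC(=O)N(CC(=O)N2CCN(c3ccccc3F)CC2)C1=O` gives 300 mg/kg in this assay.

Among the compounds with values here, compound 2 holds the highest of the two numbers; its nearest neighbour is compound 1, and the step of a 3.0-fold higher number from compound 1 to compound 2 (0.48 log units; beyond the scatter) is the only measured step, brought about by placing 2-fluorophenyl in place of 4-chlorophenyl on the amine nitrogen in the ring. Compound 3 `CC1CC(=O)N(CC(=O)N2CCN(c3ccc(Cl)c(Cl)c3)CC2)C1=O` is not yet measured. It differs from compound 2 by 3,4-dichlorophenyl in place of 2-fluorophenyl on an amine nitrogen in a ring. Within the data shown here, the one measured step bears directly on this change, since it runs from a chlorinated phenyl to 2-fluorophenyl and raised the number. Moving away from 2-fluorophenyl back to a chlorinated phenyl is therefore expected to lower the number in this assay, a step of about a 3.0-fold lower number from compound 2 to compound 3 (0.48 log units; beyond the scatter) in size. Compound 3 is estimated at 100 mg/kg, with a range from 30 mg/kg to 300 mg/kg.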

Compound 3, minimum effective dose: 300 mg/kg
Beside the measured number, compound 3's estimate is 3.0-fold (0.48 log units) below it; the measured number falls inside the stated range.
By their numbers in this assay, from the lowest: compound 1; then compounds 2 and 3 (each within the scatter of the next).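

In this assay the change from 2-fluorophenyl to 3,4-dichlorophenyl gives no change at the digits printed from compound 2 to compound 3 (within the scatter) and so shows that a chlorinated phenyl on the amine nitrogen in the ring does not by itself bring the lower number of compound 1. Adding one chloro to the 4-chlorophenyl group gives a 3.0-fold higher number from compound 1 to compound 3 (0.48 log units; beyond the scatter) in the same assay, the first step here that alters a single substituent on one phenyl, and it runs in the same direction as the change from 4-chlorophenyl to 2-fluorophenyl. Nothing available explains either step.

Still open, as far as these compounds go, is whether the chloro of the 4-chlorophenyl group is needed at all, which a plain phenyl would address. From the compounds shown here alone, it is also open whether a 3-chlorophenyl or 4-methoxyphenyl group would give a number like that of compound 1 or the higher one shared by compound 2 and compound 3.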